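This account rests on a few compounds, and the source may have more. Where it says the series, first, only, none or still open, it means among the compounds named here.

Measured so far in a functional assay on FM3A cells (Mus musculus) for inhibition, read by cell counting, with a stated time of 2 days; on this read-out lower numbers stand for stronger inhibition and higher numbers for weaker inhibition:
compound 1, `C=C(Br)C(=O)Nc1cccc(-c2cn3nc(-c4ccc(CC)cc4)sc3n2)c1`: 3300 nM
compound 2, `C=C(Br)C(=O)Nc1cccc(-c2cn3nc(-c4cccc(OC)c4)sc3n2)c1`: 500 nM
compound 3, `C=C(Br)C(=O)Nc1cccc(-c2cn3nc(-c4ccc(OC)c(OC)c4)sc3n2)c1`: 110 nM

Compound 3 stands lowest of the three numbers; the steps down to it are a 4.5-fold lower number from compound 2 to compound 3 (0.66 log units; beyond the scatter) and a 30-fold lower number from compound 1 to compound 3 (1.48 log units; beyond the scatter), both beyond the scatter.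

Compound 4, `C=C(Br)C(=O)Nc1cccc(-c2cn3nc(-c4ccc(OC)cc4)sc3n2)c1`, differs from compound 3 in one place: hydrogen in place of methoxy on an aromatic carbon. The measured step closest in kind is a 4.5-fold lower number from compound 2 to compound 3 (0.66 log units; beyond the scatter), where a methoxy enters on this ring and the number falls well beyond the scatter; here a methoxy leaves, so the reverse direction, a rise, is the working expectation. Among the compounds with values here, the match is not exact: the methoxy that leaves in going to compound 4 is the one compound 2 carries, while the one that remains in compound 4 has no measured counterpart on its own. The step of a 6.6-fold lower number from compound 1 to compound 2 (0.82 log units; beyond the scatter) shows that the pattern on this ring moves this assay substantially, so a shift beyond the scatter is plausible. For compound 4 a rise of about a 2.7-fold higher number from compound 3 to compound 4 (0.44 log units; beyond the scatter) is expected, landing between the numbers of compound 3 and compound 2.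

Compound 4 is estimated at 300 nM, in the range 110 nM to 900 nM.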

Compound 4, half-maximal inhibitory concentration: 890 nM
Compound 4: the middle estimate sits 3.0-fold (0.47 log units) below what was measured; the measured number falls inside the stated range.
By their numbers in this assay, from the lowest: compound 3; then compounds 2 and 4 (each within the scatter of the next); then compound 1.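

In this assay, the 3,4-dimethoxyphenyl pattern now stands apart from both single-methoxy neighbours: removing one methoxy gives an 8.1-fold higher number from compound 3 to compound 4 (0.91 log units; beyond the scatter), and this adds a second measured route to the drop already seen in a 4.5-fold lower number from compound 2 to compound 3 (0.66 log units; beyond the scatter). Moving the single methoxy gives a 1.8-fold higher number from compound 2 to compound 4 (0.25 log units; within the scatter), so 3-methoxyphenyl and 4-methoxyphenyl cannot be told apart in this assay, and the gain in compound 3 goes with the presence of both methoxy groups rather than with either one alone. Methoxy in place of ethyl gives a 3.7-fold lower number from compound 1 to compound 4 (0.57 log units; beyond the scatter), which isolates a change of group on a single ring carbon.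

Nothing shown explains these steps. On these data alone, whether ethoxy or hydroxy in place of either methoxy of compound 3 would keep its number remains open.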